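The compounds below may be only part of what the source reports. "The series", "measured", "known", "first", "only" and "open" are said of these compounds alone.

Measured in a functional assay on WM164 cells (Homo sapiens) for antiproliferative activity, read by sulforhodamine B assay, with a stated time of 48 h; on this read-out lower numbers stand for stronger inhibition and higher numbers for weaker inhibition
Compound 1 `CCCCCCCCCCCCNC(=O)[C@@H]1CSC(c2ccc(NC(C)=O)cc2)N1` gives 1200 nM
Compound 2 `CCCCCCCCCCCCCCNC(=O)[C@@H]1CSC(c2ccc(NC(C)=O)cc2)N1` gives 600 nM
Compound 3 `CCCCCCCCCCCCCCCCCNC(=O)[C@@H]1CSC(c2ccc(NC(C)=O)cc2)N1` gives 2400 nM

The three compounds share one core and differ only in the saturated chain on the amide nitrogen. Compound 3 is clearly separated from only one of the other two. The comparison with compound 2 shows a 4.0-fold higher number from compound 2 to compound 3 (0.60 log units; beyond the scatter) while the comparison with compound 1 shows a 2.0-fold higher number from compound 1 to compound 3 (0.30 log units; within the scatter) and so gives no real difference.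

The unmeasured compound 4 `CCCCCCCCCCCCCCCCCCNC(=O)[C@@H]1CSC(c2ccc(NC(C)=O)cc2)N1` carries methyl in place of hydrogen on a saturated chain carbon, ten or more bonds along the chain from an amide-type nitrogen.

Three measured steps are of this kind, all with larger groups entering. Ethyl gives a 2.0-fold lower number from compound 1 to compound 2 (0.30 log units; within the scatter) and pentyl gives a 2.0-fold higher number from compound 1 to compound 3 (0.30 log units; within the scatter) while propyl gives a 4.0-fold higher number from compound 2 to compound 3 (0.60 log units; beyond the scatter) as the only one beyond the scatter. These steps do not share a direction, so they offer no firm trend to extend, and methyl is smaller than any of those groups.

No shift beyond the scatter is therefore expected in this assay for this change. The expected size of the change is a 1.1-fold higher number from compound 3 to compound 4 (0.03 log units; within the scatter) in this estimate. Compound 4 is estimated at 2600 nM (expected range 1100 nM to 6000 nM).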

Compound 4, half-maximal inhibitory concentration: 11600 nM
The estimate for compound 4 lay 4.5-fold (0.65 log units) below the measured number, and the stated range ends below it.
By their numbers in this assay, from the lowest: compounds 2, 1 and 3 (each within the scatter of the next, the first and the last beyond it); then compound 4.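

In this assay, methyl in place of hydrogen on a saturated chain carbon, ten or more bonds along the chain from an amide-type nitrogen, gives a 4.8-fold higher number from compound 3 to compound 4 (0.68 log units; beyond the scatter), so at this position even a one-carbon change can move the number beyond the scatter, which the earlier steps had not shown for a group this small. The longer gaps, a 19-fold higher number from compound 2 to compound 4 (1.29 log units; beyond the scatter) and a 9.7-fold higher number from compound 1 to compound 4 (0.99 log units; beyond the scatter), set compound 4 apart from all three others with the highest number in the set, whereas compound 3 had stood clear of compound 2 only; the numbers therefore climb from compound 2 through compound 3 to compound 4, though compound 1, which lies within the scatter of both compound 2 and compound 3, does not fit a single rise along the whole series. Nothing available here bears on why the number climbs so sharply at this last chain extension.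

On these data alone, it remains open whether a longer chain would carry the number higher still or level off, and whether the sharp change belongs to chain length alone. Equally open, as far as these compounds go, is how a chain carrying an amine or a carboxylic acid would behave on the same shared core.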